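Swapping 2-cyanophenyl for 3-methylphenyl

This account rests on a few compounds, and the source may have more. Where it says the series, first, only, none or still open, it means among the compounds named here.

Of the compounds shown here, two with a shared core have numbers so far. In a functional assay (muscle tissue) with Cavia porcellus as the target (a lower number here means that less compound is needed, a higher number that more compound is needed for the effect), compound 1 `COC(=O)C1=C(C)N=C(C)/C(=C(\O)OC)C1c1cccc(OC)c1` with 3-methoxyphenyl gives 191 nM and compound 2 `COC(=O)C1=C(C)N=C(C)/C(=C(\O)OC)C1c1ccccc1C#N` with 2-cyanophenyl gives 15.9 nM as the lower of the two numbers.

Compound 3 `COC(=O)C1=C(C)N=C(C)/C(=C(\O)OC)C1c1cccc(C)c1` keeps the core and makes one change, 3-methylphenyl in place of 2-cyanophenyl on a saturated ring carbon.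

Within the data shown here, only one measured step bears on this change, and it is large: a 12-fold lower number from compound 1 to compound 2 (1.08 log units; beyond the scatter) when 2-cyanophenyl replaces 3-methoxyphenyl at that same place. Among the measured compounds shown here, compound 3 gives up that 2-cyanophenyl and takes a group whose name differs from the one in compound 1 only in methyl for methoxy. It is therefore expected to move away from compound 2 and back towards compound 1 at 191 nM in this assay without necessarily reaching it. For the measured compounds named here, one step is thin evidence, and no measurement yet compares 3-methylphenyl with 3-methoxyphenyl directly, so the range stays wide.

A higher number is expected, with a 6.9-fold higher number from compound 2 to compound 3 (0.84 log units; beyond the scatter) as the estimated step. The estimated value for compound 3 is 110 nM with a range from 30 nM to 400 nM at its ends.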

Compound 3, half-maximal effective concentration: 110 nM
The estimate for compound 3 equals the measured number at the digits printed; measured number inside the range.
By their numbers in this assay, from the lowest: compound 2; then compounds 3 and 1 (each within the scatter of the next).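

In this assay, the step of a 6.9-fold higher number from compound 2 to compound 3 (0.84 log units; beyond the scatter) shows that a second group at this saturated ring carbon, 3-methylphenyl, also fails to match the low number of 2-cyanophenyl, so among the three groups shown that low number belongs to compound 2 alone. Methyl in place of methoxy on the aromatic carbon, a 1.7-fold lower number from compound 1 to compound 3 (0.24 log units; within the scatter), stays within the scatter, so 3-methylphenyl and 3-methoxyphenyl cannot be told apart in this assay, even though the first has no hydrogen-bond acceptor in the swapped group and the second has an oxygen atom there. Nothing shown gives a measured reason for the gap between 2-cyanophenyl and the other two groups.

From the compounds shown here alone, the step from compound 2 to compound 3 changes both the group on the phenyl ring and the number in its name, so whether the low number of compound 2 goes with the nitrile itself or with where it sits stays open. Going by these compounds, how a plain phenyl, or a phenyl carrying an amine or a carboxylic acid, would behave at this ring carbon also stays open.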